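Chloro-to-nitro swap on the shorter-chain core

The source may hold more compounds than are shown below. What is called first, only, known or untested is meant among the compounds shown, and "the series" means these compounds.

Measured compounds:
compound 1 `O=C1C(=O)N(CCCCn2cc(COc3cc(=O)oc4ccccc34)nn2)c2ccc([N+](=O)[O-])cc21` gives 53% in a functional assay on HCT-116 cells (Homo sapiens) for inhibition, read by sulforhodamine B assay, with a stated time of 48 h, tested at 50 uM; a higher number here means more inhibition of growth at the concentration tested, a lower number less inhibition of growth
compound 2 `O=C1C(=O)N(CCCCn2cc(COc3cc(=O)oc4ccccc34)nn2)c2ccc(Cl)cc21` gives 62% in this assay
compound 3 `O=C1C(=O)N(CCCn2cc(COc3cc(=O)oc4ccccc34)nn2)c2ccc(Cl)cc21` gives 68% in this assay

Compound 1 and compound 2 share a core; compound 2 carries a chloro where compound 1 carries a nitro. The difference is nitro in place of chloro on an aromatic carbon and the measured step is a number 9 percentage points lower from compound 2 to compound 1 (within the scatter). Compound 3 carries the chloro on a core that differs from that of compound 2; the difference between the two cores is not broken down here. In this assay compound 3 stands nearest to compound 2 and furthest from compound 1.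

Compound 4 `O=C1C(=O)N(CCCn2cc(COc3cc(=O)oc4ccccc34)nn2)c2ccc([N+](=O)[O-])cc21` has not yet been measured. It relates to compound 3 as compound 1 relates to compound 2: nitro in place of chloro on an aromatic carbon, the same change at the same place, seen once before among these compounds. Going by the values given here, since the one measured instance of this change gave a step within the scatter, the estimate for compound 4 is a step of a number 9 percentage points lower from compound 3 to compound 4 (within the scatter) in this assay, which rests on compound 2 going to compound 1 by a number 9 percentage points lower from compound 2 to compound 1 (within the scatter). Compound 4 is thus expected at 59%, between 47% and 71%.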

Compound 4, percent growth inhibition at one concentration: 60%
Compound 4: middle estimate off by 1 percentage points, on the low side; measured number inside the range.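

On the second core, nitro in place of chloro on an aromatic carbon gives a number 8 percentage points lower from compound 3 to compound 4 (within the scatter) in this assay. Set beside the first instance, the change carries over from one core to the other with no difference in the size of the step: the same change on two cores in this assay, a number 9 percentage points lower (within the scatter) from compound 2 to compound 1 and a number 8 percentage points lower (within the scatter) from compound 3 to compound 4, 1 percentage points apart, within the scatter of two such steps. Going by these compounds alone, both steps lie within the scatter, so the agreement shows only that the swap reads alike on these two cores; it does not establish that nitro and chloro differ in this assay at all, and two cores give no basis for a rule covering others.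

The compounds shown leave open how an amine, a carboxylic acid or a nitrile at the same aromatic carbon would read, and whether the agreement would hold on a core with a longer chain. As far as these compounds go, each value is also a reading at a single concentration in one cell line, so potency across a concentration range and behaviour in other cells remain open.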